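Replacing piperazin-1-yl on the core of compound 3

A few compounds are considered here, and "the series" means these few. Any claim that something is new, unique, unknown or untested is made for them only; others in the source may bear on it.

Measured so far in a physicochemical assay for permeability, using PAMPA (on this read-out lower numbers stand for lower permeability and higher numbers for higher permeability), are these compounds:
Compound 1 `N[C@H]1CC[C@H](Nc2ccc3ncc(-c4cnc(Nc5ncccc5F)nc4)n3n2)CC1` gives 4 nm/s
Compound 2 `Cc1ccc(Nc2ncc(-c3cnc4ccc(N[C@H]5CC[C@H](N)CC5)nn34)cn2)nc1` gives "not determined" (no result reported)
Compound 3 `Fc1cccnc1Nc1ncc(-c2cnc3ccc(N4CCNCC4)nn23)cn1` gives 4 nm/s

Level with compound 1, compound 3 gives 4 nm/s in this assay and serves as the starting point here. In compound 4 `CN1CC[C@H](Nc2ccc3ncc(-c4cnc(Nc5ncccc5F)nc4)n3n2)C1` the (1-methylpyrrolidin-3-yl)amino group comes in place of piperazin-1-yl on an aromatic carbon (1-methylpyrrolidin-3-yl)amino in place of piperazin-1-yl on an aromatic carbon and the rest stays the same. Among the compounds with values here, one measured step bears on this change, namely no change at the digits printed from compound 1 to compound 3 (within the scatter) with piperazin-1-yl in place of (4-aminocyclohexyl)amino on an aromatic carbon. Compound 2 adds no number. Given that single step, the estimated 1.3-fold higher number from compound 3 to compound 4 (0.10 log units; within the scatter) is expected to stay within the scatter. Compound 4 is therefore expected at 5 nm/s in this assay with an estimated range of 2 nm/s to 15 nm/s for repeated measurements.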

Compound 4, apparent permeability: 2 nm/s
Compound 4: middle estimate off by 2.5-fold (0.40 log units), on the high side; the range from low to high includes it.
By their numbers in this assay, from the lowest: compounds 4, 1 and 3 (each within the scatter of the next).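

At this position on the shared core, in this assay, the (1-methylpyrrolidin-3-yl)amino group gives a 2.0-fold lower number from compound 3 to compound 4 (0.30 log units; within the scatter) and also a 2.0-fold lower number from compound 1 to compound 4 (0.30 log units; within the scatter) as its steps. A five-membered ring carrying one defined stereocentre therefore joins the piperazin-1-yl and (4-aminocyclohexyl)amino groups, with all three compounds lying within the scatter of one another. No measurement shown explains this result.

From the compounds shown here alone, what remains open is whether a carboxylic acid or a methoxy group at this place would take the number beyond the scatter. Going by these compounds, the mirror-image form of the (1-methylpyrrolidin-3-yl)amino group also remains open.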